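This account rests on a few compounds, and the source may have more. Where it says the series, first, only, none or still open, it means among the compounds named here.

Working notes on the series.

Compound 1 `CCCS(=O)(=O)Nc1cccc2c1CCC2c1ncc[nH]1` is the reference point here. In a functional assay on CHO cells for agonist activity at Alpha-1B adrenergic receptor (Homo sapiens), read by FLIPR and calcium flux (a higher number here means that more compound is needed for the effect, a lower number that less compound is needed), compound 1 gives > 10000 nM, which is a limit of the assay and not a number, so compound 1 stands nowhere on a scale; there is no measured value for it to be ranked against. Two other compounds have been tested in this assay. Compound 2 `Cc1c(OCC2=NCCN2)ccc(Cl)c1NS(C)(=O)=O` gives > 10000 nM, again a limit. Compound 3 `CS(=O)(=O)Nc1cccc2c1CCCC2c1ncc[nH]1` gives > 10000 nM; > 10000 nM; > 10000 nM (3 entries) across its three entries, each of them a limit. Among the compounds with values here, the only thing these measurements show is the limit of > 10000 nM in this assay, at which 2 of the 3 values shown sit: nothing has yet returned a number.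

Compound 4 `Cc1oncc1-c1cccc2c1CCC2c1ncc[nH]1` is the next candidate. It differs from compound 1 in one change, 5-methyl-1,2-oxazol-4-yl in place of (propylsulfonyl)amino on an aromatic carbon. Within the data shown here, no step between two measured compounds exists to anchor the size or direction of this change, and since compound 1 itself has only a limit, the step can be no more than a guess. The expected step from compound 1 to compound 4 in this assay is an at least 2.5-fold lower number from compound 1 to compound 4 (0.39 log units; beyond the scatter), toward a measurable value but with wide uncertainty. Compound 4 is estimated to give 4000 nM in this assay, expected to fall between 300 nM and 30000 nM.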

Compound 4, half-maximal effective concentration: > 10000 nM
Compound 4: only a limit was reported (the forecaster's own chance of this, stated with the estimate: 45%); middle value at least 2.5-fold (0.39 log units) from the limit.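

Compound 1 and compound 4 both give only limits of the assay in this assay, and no step can be read between them: the limit of > 10000 nM in this assay, at which 3 of the 4 values shown sit.

The compounds shown leave open whether 5-methyl-1,2-oxazol-4-yl in place of (propylsulfonyl)amino changes the response at all, and whether any compound of the series returns a measurable value in this assay.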